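From 3,4-dimethoxyphenyl to 3,4,5-trimethoxyphenyl

The compounds below may be only part of what the source reports. "The series", "measured", "known", "first", "only" and "open" are said of these compounds alone.

For the measured compounds named here, in a functional assay on SW480 cells (Homo sapiens) for antiproliferative activity, read by sulforhodamine B assay, with a stated time of 48 h (on this read-out lower numbers stand for stronger inhibition and higher numbers for weaker inhibition), compound 1 `COc1cccc(/C=C/C(=O)C(=Cc2ccc(F)cc2)C(=O)/C=C/c2cccc(OC)c2OC)c1OC` gives 1040 nM and compound 2 `COc1ccc(C=C(C(=O)/C=C/c2cccc(OC)c2OC)C(=O)/C=C/c2cccc(OC)c2OC)cc1OC` gives 410 nM, the lower of the two numbers so far. Compound 3 `COc1cccc(/C=C/C(=O)C(=Cc2cc(OC)c(OC)c(OC)c2)C(=O)/C=C/c2cccc(OC)c2OC)c1OC` differs from compound 2 as follows: methoxy in place of hydrogen on an aromatic carbon, turning 3,4-dimethoxyphenyl into 3,4,5-trimethoxyphenyl. Going by the values given here, the only measured step on this ring is a 2.5-fold lower number from compound 1 to compound 2 (0.40 log units; beyond the scatter), a modest change that replaced 4-fluorophenyl, so it is only a loose guide. A small move toward lower numbers in this assay, probably not beyond the scatter, is expected. The expected step is a 1.2-fold lower number from compound 2 to compound 3 (0.07 log units; within the scatter). For compound 3 the estimated value is 350 nM, with an expected range of 130 nM to 900 nM.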

Compound 3, half-maximal inhibitory concentration: 650 nM
The estimate for compound 3 lay 1.9-fold (0.27 log units) below the measured number; low and high end bracket the measured number.
By their numbers in this assay, from the lowest: compounds 2, 3 and 1 (each within the scatter of the next, the first and the last beyond it).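

In this assay, for the compounds shown here, methoxy in place of hydrogen on the 3,4-dimethoxyphenyl ring gives a 1.6-fold higher number from compound 2 to compound 3 (0.20 log units; within the scatter), so a third methoxy here produces no step that stands clear of the scatter. Going by these compounds alone, replacing 4-fluorophenyl with 3,4,5-trimethoxyphenyl gives a 1.6-fold lower number from compound 1 to compound 3 (0.20 log units; within the scatter), so of the two replacements of 4-fluorophenyl, only the one to 3,4-dimethoxyphenyl lies beyond the scatter. No available data bear on the cause of these steps. Still open, on these data alone, is whether an amine or a carboxylic acid on this ring, or an ethoxy in place of the new methoxy, would give a step beyond the scatter.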